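The source may hold more compounds than are shown below. What is called first, only, known or untested is meant among the compounds shown, and "the series" means these compounds.

Compounds measured in an assay on COS-1 cells for displacement of a labelled ligand from sodium-dependent dopamine transporter (Homo sapiens); a higher number here means a weaker inhibitor, a lower number a stronger inhibitor:
compound 1, `O=C(NCc1cccs1)C1=C(c2ccc(Cl)c(Cl)c2)CCC1`, gives 140 nM;
compound 2, `O=C(Oc1ccccc1)C1=C(c2ccc(Cl)c(Cl)c2)CCC1`, gives 170 nM.

Of these two numbers, compound 2 holds the higher one, though its step from compound 1 is small: a 1.2-fold higher number from compound 1 to compound 2 (0.08 log units; within the scatter), a change of phenoxy in place of ((thiophen-2-yl)methyl)amino on the carbonyl carbon, and the difference lies within the scatter. The next compound keeps the oxygen of compound 2 and brings back the thiophene of compound 1: compound 3, `O=C(OCc1cccs1)C1=C(c2ccc(Cl)c(Cl)c2)CCC1`, where ((thiophen-2-yl)methyl in place of phenyl on an oxygen next to a carbonyl group). For the measured compounds named here, only the step from compound 1 to compound 2 bears on this, and it was within the scatter; both compounds so far sit close together in this assay. Going by the values given here, no larger step is therefore expected here, and compound 3 is estimated at 150 nM, with a range from 60 nM to 400 nM, an expected step of a 1.1-fold lower number from compound 2 to compound 3 (0.05 log units; within the scatter).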

Compound 3, inhibition constant: 400 nM
Estimate against measurement, compound 3: 2.7-fold (0.43 log units) below, and the stated range covers the measured number.
By their numbers in this assay, from the lowest: compounds 1 and 2 (each within the scatter of the next); then compound 3.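

Within this assay, the group on this oxygen proves able to shift the result: (thiophen-2-yl)methyl in place of phenyl gives a 2.4-fold higher number from compound 2 to compound 3 (0.37 log units; beyond the scatter) and so goes beyond the scatter, which the earlier change on the carbonyl carbon did not. With the (thiophen-2-yl)methyl group held constant, the linking atom also counts, since (thiophen-2-yl)methoxy in place of ((thiophen-2-yl)methyl)amino gives a 2.9-fold higher number from compound 1 to compound 3 (0.46 log units; beyond the scatter) and thus a weaker inhibitor. Nothing available here accounts for either step.

The compounds shown do not separate the thiophene ring from the methyl link, a question that a benzyl group on the same oxygen would address. Going by these compounds, it also stays open how a phenylamino group on the carbonyl carbon would compare with the phenoxy group of compound 2.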